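The source may hold more compounds than are shown below. What is called first, only, known or untested is meant among the compounds shown, and "the series" means these compounds.

Measured compounds:
Compound 1, `CC(C)(C)OC(=O)N1CCC(O[C@H]2CC[C@H](Oc3ccc(S(C)(=O)=O)c(F)c3)CC2)CC1`: 106%
Compound 2, `CC(C)(C)OC(=O)N1CCC(O[C@H]2CC[C@H](Oc3ccc(S(C)(=O)=O)cn3)CC2)CC1`: 111%
Compound 3, `CC(C)OC(=O)N1CCC(O[C@H]2CC[C@H](Oc3ccc(S(C)(=O)=O)nc3)CC2)CC1`: 101%

All three share one core and differ only in the aromatic ring carried on the oxygen and in the ester end of the molecule. In a functional assay on isolated protein for agonist activity at Glucose-dependent insulinotropic receptor (Homo sapiens), read by HTRF and cAMP accumulation (on this read-out lower numbers stand for smaller maximal responses and higher numbers for larger maximal responses), compound 2 gives 111%, compound 1 gives 106% and compound 3 gives 101%. The number for compound 2 is not lower than either of the other two, but its distance to compound 1 and to compound 3 each falls within the usual scatter of this kind of measurement, so the three compounds cannot be told apart on these data; all of them reach a full response compared with the control.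

Compound 4, `CC(C)(C)OC(=O)N1CCC(O[C@H]2CC[C@H](Oc3ccc(S(C)(=O)=O)nn3)CC2)CC1`, is not yet measured. Going by the values given here, its only difference from compound 2 is 6-(methylsulfonyl)pyridazin-3-yl in place of 5-(methylsulfonyl)pyridin-2-yl on an oxygen on a saturated carbon. Among the compounds with values here, no measured pair shows what such an exchange does on its own, so there is no basis for expecting a shift beyond the scatter in either direction. The expected step from compound 2 to compound 4 in this assay is therefore a number 6 percentage points lower from compound 2 to compound 4 (within the scatter), essentially none. Compound 4 is estimated to give 105%, within a range from 90% to 120%.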

Compound 4, largest response reached (Emax), in percent of the reference or control that the assay uses: 97%
Compound 4: the middle estimate sits 8 percentage points above what was measured; low and high end bracket the measured number.
By their numbers in this assay, from the lowest: compounds 4, 3, 1 and 2 (each within the scatter of the next, the first and the last beyond it).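

In this assay, putting 6-(methylsulfonyl)pyridazin-3-yl in place of 5-(methylsulfonyl)pyridin-2-yl on an oxygen on a saturated carbon gives a clear single-place comparison, with a modest step: a number 14 percentage points lower from compound 2 to compound 4 (beyond the scatter). This position is therefore not indifferent to the aromatic ring it carries, even though the two groups have the same number of heavy atoms and the entering ring simply has a nitrogen where the leaving ring has a carbon; the change lowers the maximal response without abolishing it, as compound 4 still gives 97% in this read-out. Nothing shown here explains the drop.

The compounds shown leave open whether the same ring exchange would lower the response to a similar extent with a different group at the ester end of the molecule, and whether a nitrile in place of the methylsulfonyl group on the ring would preserve it. They also leave potency open, as only the largest response reached is given here.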